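The source may report more compounds than this note shows. Statements on the series, on what has been measured and on what is new or still open speak of the compounds shown alone.

Measured in an ADME assay on a cell-free system (plasma, Mus musculus) for protein binding, using equilibrium dialysis:
- compound 1 `CC(C)c1coc(-c2cccc(CNc3ccc4[nH]nc(C(=O)O)c4c3)c2O)n1`: > 99.7% (a limit, not a number)
- compound 2 `Cc1nc(-c2cccc(CN(C)c3ccc4[nH]nc(C(=O)O)c4c3)c2)sc1C`: 99.9%
- compound 3 `CN(C)c1noc(-c2cccc(CNc3ccc4[nH]nc(C(=O)O)c4c3)c2Cl)n1`: 99.4%

Compound 1 stands at the limit of > 99.7% in this assay, at which 1 of the 3 values shown sits, and this is a limit only.

Compound 4 `CC(C)c1csc(-c2cccc(CNc3ccc4[nH]nc(C(=O)O)c4c3)c2O)n1` is not yet measured. It carries 4-isopropyl-1,3-thiazol-2-yl in place of 4-isopropyl-1,3-oxazol-2-yl on an aromatic carbon. Within the data shown here, no measured pair differs in one place, so only the values themselves can guide the expectation. Compound 2 gives 99.9% and compound 3 gives 99.4%. The step that the limit leaves unreadable from compound 1 to compound 4 is expected to stay within the usual scatter of this assay, with no clear direction. For compound 4 the estimate is 99.8%, with an expected range of 99.5% to 99.95%.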

Compound 4, plasma protein binding: 100%
No number was reported for compound 4; there is nothing to compare the estimate with.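

In this assay, among these compounds, no step from compound 1 to compound 4 can be read, as compound 1 is held only by a limit: the limit of > 99.7% in this assay, at which 1 of the 4 values shown sits. The compounds shown leave open whether 4-isopropyl-1,3-thiazol-2-yl in place of 4-isopropyl-1,3-oxazol-2-yl alters plasma protein binding at all.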